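A few compounds are considered here, and "the series" means these few. Any claim that something is new, unique, unknown or untested is made for them only; others in the source may bear on it.

In a functional assay on MOLT-4 cells (Homo sapiens) for antiproliferative activity, read by sulforhodamine B assay, with a stated time of 48 h (a lower number here means a stronger inhibitor of growth, a higher number a weaker inhibitor of growth), compound 1 (`O=C(NCCCNc1cc(-c2cn(-c3ccccc3)nc2-c2cccc(O)c2)ccn1)Nc1ccc(F)cc1`) gives 15600 nM. Among the compounds with values here, compound 2 (`O=C(NCCCNc1cc(-c2cn(-c3ccccc3)nc2-c2cccc(O)c2)ccn1)Nc1cccc(C(F)(F)F)c1`) gives 15000 nM, so compound 1 stands level with the only other measured member of the series, and the two values lie within the scatter of each other.

Compound 3 (`COc1cccc(-c2nn(-c3ccccc3)cc2-c2ccnc(NCCCNC(=O)Nc3ccc(F)cc3)c2)c1`) keeps the 4-fluorophenyl group of compound 1 and differs from it in one place: methyl in place of hydrogen on an oxygen on an aromatic ring. This is methyl in place of hydrogen on an oxygen on an aromatic ring, reading as 3-methoxyphenyl in place of 3-hydroxyphenyl.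

Within the data shown here, the one measured step, a 1.0-fold lower number from compound 1 to compound 2 (0.02 log units; within the scatter), lies within the scatter, but it concerns a different place, on an amide-type nitrogen. Among the measured compounds shown here, it shows only that one change elsewhere left this assay flat. For the measured compounds named here, no measured step covers the oxygen itself, so the direction remains open and the range must stay wide. No step beyond the scatter is expected, with at most a slight lean towards a higher number.

The estimated step is a 1.2-fold higher number from compound 1 to compound 3 (0.06 log units; within the scatter).

For compound 3 the expected value is 18000 nM, within an estimated range of 7000 nM to 45000 nM.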

Compound 3, concentration for total growth inhibition: 19000 nM
Compound 3: the middle estimate sits 1.1-fold (0.02 log units) below what was measured; measured number inside the range.
By their numbers in this assay, from the lowest: compounds 2, 1 and 3 (each within the scatter of the next).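

In this assay the oxygen on the aromatic ring now has a measured step of its own: a 1.2-fold higher number from compound 1 to compound 3 (0.09 log units; within the scatter). Within the data shown here, until now the only step concerned the amide-type nitrogen, so this pair adds that replacing 3-hydroxyphenyl with 3-methoxyphenyl, which takes away the hydrogen on that oxygen, leaves compound 3 level with compound 1 within the scatter; for this pair, then, a free hydroxy group is not needed to hold the number in this range. No measurement shown here explains the size of this step.

From the compounds shown here alone, whether other groups on this position would leave the number as flat stays open, for instance an amine or a carboxylic acid in place of the hydroxy, or a longer chain such as ethoxy in place of methoxy. Also open, going by these compounds, is whether the methoxy group and the 3-(trifluoromethyl)phenyl group of compound 2, taken together on the core of compound 1, would stay level with these compounds or give a step beyond the scatter.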